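From Pyrrolidin-1-yl to (3-Fluorophenyl)amino on a Fused Core

A few compounds are considered here, and "the series" means these few. Any claim that something is new, unique, unknown or untested is made for them only; others in the source may bear on it.

Measured compounds:
compound 1, `O=C1C(N2CCCC2)=CC(=O)c2c1nc1n2[C@H]2OC[C@@H](O)[C@H]2OC1`: > 16000 nM
compound 2, `O=C1C=C(Nc2cccc(F)c2)C(=O)c2c1nc1n2[C@H]2OC[C@@H](O)[C@H]2OC1`: 2180 nM

Two compounds sharing one fused core were tested in a functional assay on MGC-803 cells (Homo sapiens) for inhibition, read by sulforhodamine B assay; a lower number here means a stronger inhibitor, a higher number a weaker inhibitor. Compound 1 carries a pyrrolidin-1-yl group on a double-bonded ring carbon and gives > 16000 nM, which is a limit of this assay and not a number, so compound 1 stands at the weak end of the values shown (the limit of > 16000 nM in this assay, at which 1 of the 2 values shown sits). Compound 2 carries a (3-fluorophenyl)amino group on the other double-bonded ring carbon and gives 2180 nM in this assay.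

The unmeasured compound 3, `O=C1C(Nc2cccc(F)c2)=CC(=O)c2c1nc1n2[C@H]2OC[C@@H](O)[C@H]2OC1`, differs from compound 1 in one place: (3-fluorophenyl)amino in place of pyrrolidin-1-yl on a double-bonded ring carbon. Compound 3 is thereby the regioisomer of compound 2, bearing the same group on the carbon where compound 1 holds its pyrrolidin-1-yl.

Among the compounds with values here, since compound 1 gives only a limit, no measured step exists to anchor the change. The estimated step is an at least 4.5-fold lower number from compound 1 to compound 3 (0.66 log units; beyond the scatter). Compound 3 is estimated at 3500 nM, between 1000 nM and 14000 nM.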

Compound 3, half-maximal inhibitory concentration: 1470 nM
For compound 3 the middle estimate is 2.4-fold (0.38 log units) above the measured one; low and high end bracket the measured number.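

Until now, the shared core had given no measured change at this double-bonded ring carbon. In this assay, placing (3-fluorophenyl)amino there in place of pyrrolidin-1-yl gives an at least 10-fold lower number from compound 1 to compound 3 (1.03 log units; beyond the scatter), so the group on this carbon alone separates a compound with a readable value from one without. The size of this step is open at one end, as the value for compound 1 is a limit of the assay and not a number: the limit of > 16000 nM in this assay, at which 1 of the 3 values shown sits.

The change swaps a five-membered non-aromatic ring for a six-membered aromatic ring of carbon only and also brings in a hydrogen-bond donor, so this pair cannot tell which of these differences goes with the step. A cyclopentylamino group, a plain phenylamino group without the fluorine, or a piperidin-1-yl group on the same carbon would pull these apart, and the compounds shown leave open what each of them would give.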